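Methoxy in place of ethyl on compound 1

The source may hold more compounds than are shown below. What is called first, only, known or untested is meant among the compounds shown, and "the series" means these compounds.

Measured so far in a physicochemical assay for lipophilicity, read by LC-MS, using the shake flask method, in phosphate buffer, with a stated time of 50 min, at pH 7.4 (on this read-out lower numbers stand for lower lipophilicity and higher numbers for higher lipophilicity), are three compounds:
Compound 1 `CCCC(=O)OCCCCCC(=O)N[C@H](C(=O)N1C[C@H](O)C[C@H]1C(=O)NCc1ccc(-c2scnc2C)cc1)C(C)(C)C` gives 0.5 as its value
Compound 2 `CCCC(=O)NCCCCCC(=O)N[C@H](C(=O)N1C[C@H](O)C[C@H]1C(=O)NCc1ccc(-c2scnc2C)cc1)C(C)(C)C` gives 2.2 as its value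
Compound 3 `Cc1ncsc1-c1ccc(CNC(=O)[C@@H]2C[C@@H](O)CN2C(=O)[C@@H](NC(=O)CCCCCNC(=O)CC(c2ccccc2)c2ccccc2)C(C)(C)C)cc1` gives 0.3 as its value

On these numbers compound 1 lies within the scatter of compound 3, and both stand clearly under compound 2. Compound 4 `COCC(=O)OCCCCCC(=O)N[C@H](C(=O)N1C[C@H](O)C[C@H]1C(=O)NCc1ccc(-c2scnc2C)cc1)C(C)(C)C` has not yet been measured. Its difference from compound 1 is methoxy in place of ethyl on a saturated chain carbon bound to a carbonyl carbon with methoxy in place of ethyl on a saturated chain carbon bound to a carbonyl carbon.

Going by the values given here, only one measured step starts from compound 1. It is a number 1.70 log units higher from compound 1 to compound 2 (beyond the scatter) with (propylcarbonyl)amino in place of (propylcarbonyl)oxy. Among the compounds with values here, that is a different change, and no measured step swaps ethyl for methoxy, so it serves only as a loose guide. A smaller step toward lower numbers is expected in this assay for this change. The estimated step is a number 0.40 log units lower from compound 1 to compound 4 (beyond the scatter) with wide uncertainty. Compound 4 is estimated at 0.1 with an expected range from -0.6 to 0.7 in this assay.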

Compound 4, distribution coefficient: 1.7
The estimate for compound 4 lay 1.60 log units below the measured number; the measured number lies above the stated range.
By their numbers in this assay, from the lowest: compounds 3 and 1 (each within the scatter of the next); then compound 4; then compound 2.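

In this assay this position proves far from silent: methoxy in place of ethyl on a saturated chain carbon bound to a carbonyl carbon gives a number 1.20 log units higher from compound 1 to compound 4 (beyond the scatter) even though the heavy-atom count stays the same and one hydrogen-bond acceptor enters, so the earlier large step is not the only route to a higher number on this chain. With the oxy link kept, most of the gap to the amino compound closes but not all of it, with a number 0.50 log units lower from compound 2 to compound 4 (beyond the scatter) still standing beyond the scatter. No measured evidence bears on why the number moves this way.

The compounds shown leave open whether the same methoxy swap would give a comparable step on compound 2, which carries the amino link. They also leave open how this carbon responds to other groups in place of ethyl, such as an amine, a carboxylic acid or a longer chain.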